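Carbonyl-side aryl swaps in a quinoline-derived enone series

A few compounds are considered here, and "the series" means these few. Any claim that something is new, unique, unknown or untested is made for them only; others in the source may bear on it.

Measured so far:
- compound 1, `COc1ccc(-c2cc3ccccc3nc2/C=C/C(=O)c2ccc(OC)cc2OC)cc1`: 6110 nM
- compound 2, `COc1ccc(-c2cc3ccccc3nc2/C=C/C(=O)c2c(OC)cccc2OC)cc1`: 4470 nM
- compound 3, `COc1ccc(-c2cc3ccccc3nc2/C=C/C(=O)c2ccco2)cc1`: 6240 nM

All three share a core and differ only in the group on the carbonyl carbon. In a functional assay on H184B5F5/M10 cells (Homo sapiens) for antiproliferative activity, read by XTT assay, with a stated time of 72 h (a lower number here means a stronger inhibitor, a higher number a weaker inhibitor), compound 2 gives the smallest of the three numbers, yet the steps of a 1.4-fold lower number from compound 1 to compound 2 (0.14 log units; within the scatter) and a 1.4-fold higher number from compound 2 to compound 3 (0.14 log units; within the scatter) are both within the scatter, so the three compounds cannot be ranked against each other. The step of a 1.0-fold higher number from compound 1 to compound 3 (0.01 log units; within the scatter) is likewise flat.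

Compound 4, `COc1ccc(-c2cc3ccccc3nc2/C=C/C(=O)c2c[nH]c3ccccc23)cc1`, is not yet measured. Its change from compound 2 is 1H-indol-3-yl in place of 2,6-dimethoxyphenyl on a carbonyl carbon. For the measured compounds named here, the three measured steps all concern the same position and all lie within the scatter, which is the only guide here: a dimethoxyphenyl moved between two substitution patterns, and a furan-2-yl in place of either, left the number essentially unchanged. Nothing measured speaks to a 1H-indol-3-yl specifically. The step of a 1.1-fold higher number from compound 2 to compound 4 (0.05 log units; within the scatter) is therefore expected to stay within the scatter, in no particular direction. Compound 4 is estimated at 5000 nM, with a range of 2000 nM to 13000 nM.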

Compound 4, half-maximal inhibitory concentration: > 10000 nM
Compound 4 was reported as a limit; the forecaster's own chance of this, stated with the estimate: 5%; middle value at least 2.0-fold (0.30 log units) from the limit.
By their numbers in this assay, from the lowest: compounds 2, 1 and 3 (each within the scatter of the next). At a limit, above all of these: compound 4.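

In this assay, compound 4 stands at a limit and not at a number: the limit of > 10000 nM in this assay, at which 1 of the 4 values shown sits. For the compounds shown here, the carbonyl-carbon position is thus not indifferent to every swap: 1H-indol-3-yl in place of 2,6-dimethoxyphenyl gives an at least 2.2-fold higher number from compound 2 to compound 4 (0.34 log units; beyond the scatter) and this is the only step that leaves the scatter, whereas the steps among the dimethoxyphenyl and furan-2-yl groups all stayed within it. Neither an at least 1.6-fold higher number from compound 1 to compound 4 (0.21 log units; that floor lies within the scatter) nor an at least 1.6-fold higher number from compound 3 to compound 4 (0.20 log units; that floor lies within the scatter) shows a difference beyond the scatter at its floor.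

As far as these compounds go, the true size of the step to compound 4 stays open beyond its floor. Also open, from the compounds shown here alone, is whether a 1-methyl-1H-indol-3-yl or a benzofuran-3-yl on the same carbonyl carbon would track with compound 4 or with compound 2.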